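The source may hold more compounds than are shown below. What is called first, only, known or untested is meant among the compounds shown, and "the series" means these compounds.

Measured compounds:

Compound 1, `O=C(O)CSC(CCCc1ccc(Cl)cc1)c1ccc(OCc2ccc3ccccc3n2)cc1`: 7 nM
Compound 2, `O=C(O)/C=N/OC(c1ccc(OCc2nc3cccnc3s2)cc1)C1CCCCC1`: 27 nM
Compound 3, `O=C(O)/C=N/OC(c1ccc(OCc2nc(-c3ccccc3)cs2)cc1)C1CCCCC1`: 21 nM

All three were tested in a functional assay for inhibition of Polyunsaturated fatty acid 5-lipoxygenase (Homo sapiens); on this read-out lower numbers stand for stronger inhibition and higher numbers for weaker inhibition. Among them compound 2 gives the highest number. The gap to compound 3 lies within the scatter of repeated measurements, so the two cannot be told apart on this read-out. The gap to compound 1 lies beyond the scatter, and compound 1 gives the lower number of the two.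

The next compound, compound 4, `O=C(O)/C=N/OC(c1ccc(OCc2nc3ccccc3s2)cc1)C1CCCCC1`, has not yet been measured in this assay. It differs from compound 2 in one place: a group of 9 heavy atoms (7 carbon, 1 nitrogen, 1 sulfur; one five-membered aromatic ring with 2 hetero atoms, one six-membered aromatic ring of carbon only) in place of a group of 9 heavy atoms (6 carbon, 2 nitrogen, 1 sulfur; one five-membered aromatic ring with 2 hetero atoms, one six-membered aromatic ring with 1 hetero atom), on a saturated chain carbon bound to an oxygen on an aromatic ring. The rest of the molecule, including the acid-bearing chain and the cyclohexyl group, is unchanged.

For the measured compounds named here, no measured pair differs in exactly this way, so the size of the step has to be guessed. Compound 3, which carries yet another two-ring group at the same place and gives 21 nM, sits within the scatter of compound 2, which suggests that swapping these groups moves the number little. On that basis no step beyond the scatter is expected, perhaps a slight move toward a lower number. Compound 4 is therefore estimated at 20 nM, with a range from 7 nM to 60 nM. The expected step of a 1.4-fold lower number from compound 2 to compound 4 (0.13 log units; within the scatter) stays within the usual scatter.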

Compound 4, half-maximal inhibitory concentration: 60 nM
For compound 4 the middle estimate is 3.0-fold (0.48 log units) below the measured one; low and high end bracket the measured number.
By their numbers in this assay, from the lowest: compound 1; then compounds 3 and 2 (each within the scatter of the next); then compound 4.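

At the saturated chain carbon bound to an oxygen on an aromatic ring, putting 1,3-benzothiazol-2-yl in place of the earlier two-ring group gives a 2.2-fold higher number from compound 2 to compound 4 (0.35 log units; beyond the scatter) in this assay. The two groups have the same ring types and the same number of heavy atoms, and they differ only in that one nitrogen of the six-membered ring becomes a carbon, which takes the count of hydrogen-bond acceptors in the group from 3 to 2, so this place can respond to a change of a single ring atom and not only to a change of the whole group. Nothing available explains why this one atom change moves the number, so the step stands as an observation without a cause.

Going by these compounds, it remains open whether an amine or a fluorine on the 1,3-benzothiazol-2-yl group would bring the number back down. On these data alone, it is equally open whether the same change of ring atom would give a step of similar size if a longer chain stood in place of the cyclohexyl group.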